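Acylguanidine series: replacing the aryl neighbour of the methylsulfonyl group

This account rests on a few compounds, and the source may have more. Where it says the series, first, only, none or still open, it means among the compounds named here.

Measured compounds:
compound 1 `Cc1cc(C2CCCCC2)c(S(C)(=O)=O)cc1C(=O)N=C(N)N`, 22 nM
compound 2 `Cc1cc(-c2cc(Cl)cc(Cl)c2)c(S(C)(=O)=O)cc1C(=O)N=C(N)N`, 130 nM
compound 3 `Cc1cc(-c2ccco2)c(S(C)(=O)=O)cc1C(=O)N=C(N)N`, 16 nM

In a functional assay for inhibition of sodium/hydrogen exchanger (Oryctolagus cuniculus) (on this read-out higher numbers stand for weaker inhibition and lower numbers for stronger inhibition), compound 3 gives the lowest number of the three; compound 1 lies within the scatter of it, while compound 2 sits clearly higher, an 8.1-fold lower number from compound 2 to compound 3 (0.91 log units; beyond the scatter).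

Compound 4 `Cc1cc(O)c(S(C)(=O)=O)cc1C(=O)N=C(N)N` carries the change (hydroxy in place of furan-2-yl on an aromatic carbon). Within the data shown here, the steps that bear on it are those at the same position: a 1.4-fold lower number from compound 1 to compound 3 (0.14 log units; within the scatter) and an 8.1-fold lower number from compound 2 to compound 3 (0.91 log units; beyond the scatter). Neither removes a ring for a single-atom group, so the size of the step is uncertain. Since every measured compound keeps a ring at this carbon, the number for compound 4 is expected to move higher, by a 13-fold higher number from compound 3 to compound 4 (1.10 log units; beyond the scatter). Compound 4 is estimated at 200 nM, range 40 nM to 1500 nM.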

Compound 4, half-maximal inhibitory concentration: 220 nM
Compound 4: middle estimate off by 1.1-fold (0.04 log units), on the low side; the measured number falls inside the stated range.
By their numbers in this assay, from the lowest: compounds 3 and 1 (each within the scatter of the next); then compounds 2 and 4 (each within the scatter of the next).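

Replacing furan-2-yl or cyclohexyl with hydroxy at this carbon, ortho to the methylsulfonyl group, costs much of the inhibition (a 14-fold higher number from compound 3 to compound 4 (1.14 log units; beyond the scatter); a 10-fold higher number from compound 1 to compound 4 (1.00 log units; beyond the scatter)). Replacing 3,5-dichlorophenyl with hydroxy stays within the scatter (a 1.7-fold higher number from compound 2 to compound 4 (0.23 log units; within the scatter)), so keeping a ring here does not by itself give a low number, as compound 2 shows. No measured evidence bears on why these steps differ.

Open, as far as these compounds go, is whether an amino or methoxy group at this carbon would fall with compound 4 or with compound 3. Also open, from the compounds shown here alone, is where an unsubstituted phenyl ring would fall relative to compound 2.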